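Benzyl Ester in Place of an Acid Side Chain

The source may report more compounds than this note shows. Statements on the series, on what has been measured and on what is new or still open speak of the compounds shown alone.

Going by the values given here, compound 1 `Cc1cn([C@@H]2O[C@H](CO[Si](C)(C)C(C)(C)C)[C@@]3(OS(=O)(=O)C=C3NCC(=O)O)[C@H]2O[Si](C)(C)C(C)(C)C)c(=O)n(C)c1=O` is the only member of this set with a plain number: in a functional assay on HEL cells (Homo sapiens) for cytotoxicity, read by microscopy (a higher number here means that more compound is tolerated, a lower number that less compound is tolerated), compound 1 gives 300000 nM. Compound 2 `CC(=O)NC1=CS(=O)(=O)O[C@@]12[C@@H](CO[Si](C)(C)C(C)(C)C)O[C@@H](n1cc(C)c(=O)n(C)c1=O)[C@@H]2O[Si](C)(C)C(C)(C)C` reaches only a limit of the assay, >= 80000 nM. Compound 3 `Cc1cn([C@@H]2O[C@H](CO[Si](C)(C)C(C)(C)C)[C@@]3(OS(=O)(=O)C=C3NC(=O)NC(=O)c3ccccc3)[C@H]2O[Si](C)(C)C(C)(C)C)c(=O)n(C)c1=O` likewise stops at a limit, >= 80000 nM. Because of the limit of >= 80000 nM in this assay, at which 2 of the 3 values shown sit, the steps a step that the limit leaves unreadable from compound 1 to compound 2 and a step that the limit leaves unreadable from compound 1 to compound 3 cannot be read, and neither can a step that the two limits leave unreadable from compound 2 to compound 3. Compound 4 `Cc1cn([C@@H]2O[C@H](CO[Si](C)(C)C(C)(C)C)[C@@]3(OS(=O)(=O)C=C3NCCC(=O)OCc3ccccc3)[C@H]2O[Si](C)(C)C(C)(C)C)c(=O)n(C)c1=O` differs from compound 1 by (benzyloxycarbonyl)methyl in place of carboxy on a saturated chain carbon bound to an amine nitrogen; cut one bond further out, the change reads carboxymethyl to 2-(benzyloxycarbonyl)ethyl. Among the compounds with values here, no measured step bears readably on this change, so no shift beyond the scatter is expected, and the step of a 1.5-fold lower number from compound 1 to compound 4 (0.18 log units; within the scatter) is an estimate of that. Compound 4 is expected to give 200000 nM, between 50000 nM and 400000 nM.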

Compound 4, minimum cytotoxic concentration: >= 400000 nM
Compound 4 gave a limit, no number; the forecaster's own chance of this, stated with the estimate: 50%; middle value at least 2.0-fold (0.30 log units) away from the limit.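

Compound 4 stops at a limit of this assay, >= 400000 nM, and gives no number. Even so, the change on the saturated chain carbon bound to an amine nitrogen can be read as an at least 1.3-fold higher number from compound 1 to compound 4 (0.12 log units; that floor lies within the scatter), showing that this position carries the benzyl ester, with no loss of tolerated concentration. The steps from compound 2 and compound 3 to compound 4 cannot be read.

The compounds shown leave open whether the longer chain or the benzyl ester matters more, a question a 2-carboxyethyl group on the amine nitrogen would separate. As far as these compounds go, how far compound 4 lies past its limit also stays open.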